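The compounds below may be only part of what the source reports. "The series", "measured", "known", "first", "only" and "open" are said of these compounds alone.

Three compounds from this series have so far been examined in a functional assay on HCT-116 cells (Homo sapiens), read by MTT assay, with a stated time of 72 h; on this read-out higher numbers stand for weaker inhibition and lower numbers for stronger inhibition. Compound 1 `Cc1nc(N)c2c(-c3cccs3)cn([C@@H]3O[C@H](CO)[C@@H](O)[C@H]3O)c2n1` gives only the limit of the assay, > 20000 nM. Compound 2 `Cc1nc(N)c2c(-c3ccco3)cn([C@@H]3O[C@H](CO)[C@@H](O)[C@H]3O)c2n1` likewise gives a limit in this assay, > 20000 nM. Compound 3 `Nc1nc2c(c(-c3ccco3)cn2[C@@H]2O[C@H](CO)[C@@H](O)[C@H]2O)c(=O)[nH]1` also gives no more than a limit in this assay, > 20000 nM. The difference between the cores of compound 2 and compound 3 is not broken down here. Compound 1 and compound 2 are separated by thiophen-2-yl in place of furan-2-yl on an aromatic carbon, and the step that the two limits leave unreadable from compound 2 to compound 1 cannot be read, since both ends sit at the limit of > 20000 nM in this assay, at which 3 of the 3 values shown sit.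

Compound 4 `Nc1nc2c(c(-c3cccs3)cn2[C@@H]2O[C@H](CO)[C@@H](O)[C@H]2O)c(=O)[nH]1` has not yet been measured in this assay; it differs from compound 3 by thiophen-2-yl in place of furan-2-yl on an aromatic carbon, which is the same change that separates compound 2 from compound 1. Compound 4 is expected to give 30000 nM. The expected step that the limit leaves unreadable from compound 3 to compound 4 is small because compound 3 sits at the limit of > 20000 nM in this assay, at which 3 of the 3 values shown sit, and the earlier pair also ended at the limit of > 20000 nM in this assay, at which 3 of the 3 values shown sit. The estimated range for compound 4 runs from 8000 nM to 100000 nM, with a limit rather than a number the more likely outcome.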

Compound 4, half-maximal inhibitory concentration: > 20000 nM
Compound 4: a limit, no number; the forecaster's own chance of this, stated with the estimate: 85%; the middle value lies beyond the limit too.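

Compound 4, like compound 3, gives only a limit, so no step can be read between compound 3 and compound 4 in this assay: the limit of > 20000 nM in this assay, at which 4 of the 4 values shown sit. The compounds shown leave open how strongly any of them inhibits in this assay, and whether thiophen-2-yl and furan-2-yl differ at all on either core.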